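Replacing the Oxetane Ring on a Sulfonamide Side Chain

The source may report more compounds than this note shows. Statements on the series, on what has been measured and on what is new or still open speak of the compounds shown alone.

Compound 1, `CC1(C)C[C@H](CN([C@H](CCC(F)(F)F)C(N)=O)S(=O)(=O)c2ccc(Cl)cc2)O1`: 29 mL/min/kg
Compound 2, `NC(=O)[C@@H](CCC(F)(F)F)N(CC1CCCC1)S(=O)(=O)c1ccc(Cl)cc1`: 229 mL/min/kg
Compound 3, `NC(=O)[C@@H](CCC(F)(F)F)N(C[C@@H]1CCCOC1)S(=O)(=O)c1ccc(Cl)cc1`: 136 mL/min/kg

Three compounds share one core and differ only in the ring carried on a saturated chain carbon bound to a sulfonamide nitrogen. In an in vitro ADME assay on microsomes from liver (Homo sapiens) for metabolic stability, read by HPLC (a lower number here means slower removal, a higher number faster removal of the compound), compound 1 gives 29 mL/min/kg, the lowest of the three numbers, so it is the one removed most slowly. Both ring swaps away from compound 1 raised the number: a 7.9-fold higher number from compound 1 to compound 2 (0.90 log units; beyond the scatter), and a 4.7-fold higher number from compound 1 to compound 3 (0.67 log units; beyond the scatter). Between the two higher compounds the gap is small, a 1.7-fold lower number from compound 2 to compound 3 (0.23 log units; within the scatter), so compound 2 and compound 3 cannot be told apart here.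

Compound 4, `NC(=O)[C@@H](CCC(F)(F)F)N(C[C@@H]1COCCO1)S(=O)(=O)c1ccc(Cl)cc1`, has not yet been measured. It differs from compound 1 in one place: 1,4-dioxan-2-yl in place of 4,4-dimethyloxetan-2-yl on a saturated chain carbon bound to a sulfonamide nitrogen. Within the data shown here, the two measured steps that bear on this, a 7.9-fold higher number from compound 1 to compound 2 (0.90 log units; beyond the scatter) and a 4.7-fold higher number from compound 1 to compound 3 (0.67 log units; beyond the scatter), both took the number upward by a modest amount when the 4,4-dimethyloxetan-2-yl ring was exchanged for another saturated ring, while no measured step distinguishes one replacement ring from another beyond the scatter. A rise in this assay is therefore expected for compound 4 as well, probably of a size between those two steps, that is a 2.6-fold higher number from compound 1 to compound 4 (0.41 log units; beyond the scatter). The estimate for compound 4 is 75 mL/min/kg, with a likely range from 32 mL/min/kg to 175 mL/min/kg.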

Compound 4, clearance: 117 mL/min/kg
Beside the measured number, compound 4's estimate is 1.6-fold (0.19 log units) below it; the measured number falls inside the stated range.
By their numbers in this assay, from the lowest: compound 1; then compounds 4, 3 and 2 (each within the scatter of the next).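

In this assay the exchange gives a 4.0-fold higher number from compound 1 to compound 4 (0.61 log units; beyond the scatter) with 1,4-dioxan-2-yl as the new ring, so all three replacements of the 4,4-dimethyloxetan-2-yl ring at this position now raise the number, and no compound shown goes against that pattern. Compound 4 groups with the other replacements, with a 1.2-fold lower number from compound 3 to compound 4 (0.07 log units; within the scatter) against the oxan-3-yl ring and a 2.0-fold lower number from compound 2 to compound 4 (0.29 log units; within the scatter) against the cyclopentyl ring, so these three rings cannot be told apart here even though they differ in their ring oxygens. No measured information is available to explain why compound 1 stands apart from the other three.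

Each replacement changes the four-membered ring and removes the dimethyl substitution together, so the compounds shown leave open which of these two differences goes with the lower number of compound 1. A plain oxetan-2-yl ring without the methyl groups would separate the two, while an amine such as a piperidine ring on the same saturated chain carbon would show whether a basic nitrogen in the ring fits the same pattern.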